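Replacing the hydroxyphenyl group with 2-phenylethenyl

This account rests on a few compounds, and the source may have more. Where it says the series, first, only, none or still open, it means among the compounds named here.

Compound 1 `O=C(CSc1nnc(-c2ccncc2)o1)N/N=C/c1cc(Cl)ccc1O`: 3970 nM
Compound 2 `O=C(CSc1nnc(-c2ccncc2)o1)N/N=C/c1cc(Br)ccc1O`: 6490 nM

Among the compounds with values here, in a functional assay on HepG2 cells (Homo sapiens) for cytotoxicity, read by MTT assay, with a stated time of 48 h (a lower number here means a stronger inhibitor, a higher number a weaker inhibitor), compound 2 gives 6490 nM and cannot be separated from compound 1, since the only measured step, a 1.6-fold higher number from compound 1 to compound 2 (0.21 log units; within the scatter), lies within the scatter. Compound 3 `O=C(CSc1nnc(-c2ccncc2)o1)N/N=C/C=C/c1ccccc1` carries a larger change: 2-phenylethenyl in place of 5-bromo-2-hydroxyphenyl on a carbon with a double bond to nitrogen. In words, 2-phenylethenyl stands in place of 5-bromo-2-hydroxyphenyl on a carbon with a double bond to nitrogen. Within the data shown here, the halogen exchange bears on this only weakly, as no measured step removes or replaces the whole group. The anchor is therefore compound 2 at 6490 nM, and the range must stay wide. In this assay the expected change is a 1.4-fold higher number from compound 2 to compound 3 (0.14 log units; within the scatter), an estimate leaning towards a higher number, though without firm support. Compound 3 is estimated at 9000 nM, with an expected range of 2500 nM to 35000 nM.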

Compound 3, half-maximal inhibitory concentration: 7420 nM
For compound 3 the middle estimate is 1.2-fold (0.08 log units) above the measured one, within the range that was stated.
By their numbers in this assay, from the lowest: compounds 1, 2 and 3 (each within the scatter of the next).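

In this assay 2-phenylethenyl in place of 5-bromo-2-hydroxyphenyl gives a 1.1-fold higher number from compound 2 to compound 3 (0.06 log units; within the scatter) and in place of 5-chloro-2-hydroxyphenyl gives a 1.9-fold higher number from compound 1 to compound 3 (0.27 log units; within the scatter) on a carbon with a double bond to nitrogen. Where the earlier pair tested only a halogen exchange, these steps replace the whole group: hydroxyl and halogen both leave, the entering group has 0 hydrogen-bond donors and 0 hydrogen-bond acceptors, and the numbers stay within the scatter. No accompanying measurement bears on why this exchange leaves the read-out unresolved.

The hydroxyl and the halogen leave together here, so the compounds shown do not separate their contributions. From the compounds shown here alone, whether an amine, a carboxylic acid or a longer chain on this carbon would stay within the same scatter also remains open.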